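From 3-Carbamoylphenyl to 3,5-Dimethylphenyl on Compound 1

The source may hold more compounds than are shown below. What is called first, only, known or untested is meant among the compounds shown, and "the series" means these compounds.

Compound 1, `Cc1nc(-c2ccccc2)c(C(=O)N2CCN(c3cccc(C(N)=O)c3)CC2)o1`, is the anchor of this small set. For the measured compounds named here, in a functional assay on HL-60 cells (Homo sapiens) for inhibition, read by MTT assay, with a stated time of 72 h (a higher number here means a weaker inhibitor, a lower number a stronger inhibitor), compound 1 gives 71 nM, and that is the only plain number reported among the three measured compounds. Compound 2, `CC(C)(C)c1nc(-c2ccccc2F)c(C(=O)N2CCN(c3cccc(Cl)c3)CC2)o1`, is reported in this assay only as a limit, > 1000 nM. Compound 3, `O=C(c1oc(C(F)(F)F)nc1-c1ccc(F)cc1)N1CCN(c2cccc(Cl)c2)CC1`, is reported in this assay as "not active" (no number reported), with no number at all. So compound 1 stands alone with a measured value, and the other two entries tell only that they were weaker than the edge of what the assay resolves, as the limit of > 1000 nM in this assay, at which 1 of the 3 values shown sits, shows.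

Compound 4, `Cc1cc(C)cc(N2CCN(C(=O)c3oc(C)nc3-c3ccccc3)CC2)c1`, differs from compound 1 in one place: 3,5-dimethylphenyl in place of 3-carbamoylphenyl on an amine nitrogen in a ring. The group that leaves carries one hydrogen-bond donor and one hydrogen-bond acceptor, and the group that enters carries none. Going by the values given here, no measured pair in the set isolates this change, so the expectation rests on compound 1 alone. The step from compound 1 to compound 4 is expected to be a 4.2-fold higher number from compound 1 to compound 4 (0.63 log units; beyond the scatter), toward a weaker inhibitor, and clearly beyond the scatter. Compound 4 is therefore estimated at 300 nM, within a range from 80 nM to 1500 nM.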

Compound 4, half-maximal inhibitory concentration: 34.5 nM
Compound 4: middle estimate off by 8.7-fold (0.94 log units), on the high side; measured number below the stated range.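

For the compounds shown here, replacing 3-carbamoylphenyl with 3,5-dimethylphenyl gives a 2.1-fold lower number from compound 1 to compound 4 (0.31 log units; beyond the scatter) in this assay, the first step in this set that isolates a single change. This shows that the carbamoyl group is not required for activity at this position on the amine nitrogen in a ring, since a phenyl carrying two methyl groups, with no hydrogen-bond donor or acceptor, gives the stronger inhibitor of this pair, if only modestly. Nothing reported here explains why the number falls, as the data include no measurement that bears on the cause of this step.

The compounds shown leave open which part of the exchange matters. A ring with a single methyl group, or with a carboxylic acid or an amine in place of the carbamoyl group, would separate the loss of the carbamoyl group from the gain of the two methyl groups. They also leave open how 3-chlorophenyl, which compound 2 and compound 3 carry alongside other changes, would behave on the otherwise unchanged structure of compound 1, and whether the same step would hold with a different group elsewhere on the shared core.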